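The source may hold more compounds than are shown below. What is called first, only, known or untested is meant among the compounds shown, and "the series" means these compounds.

Measured compounds in a functional assay on HCT-116 cells (Homo sapiens) for inhibition; a lower number here means a stronger inhibitor, a higher number a weaker inhibitor: compound 1 `CC(C)=CC[C@@H]1C[C@]2(CC=C(C)C)C(=O)[C@@](CC=C(C)C)(C(=O)C(C(=O)c3ccc(O)c(O)c3)=C2O)C1(C)C` with 9.22 ug/mL; compound 2 `CC(C)=CCC/C(C)=C/C[C@@H]1C[C@]2(C/C=C(\C)CCC=C(C)C)C(=O)[C@@](CC=C(C)C)(C(=O)C(C(=O)c3ccc(O)c(O)c3)=C2O)C1(C)C` with 4.92 ug/mL; compound 3 `CC(C)=CCC/C(C)=C/C[C@]12C[C@@H](CC=C(C)C)C(C)(C)[C@](C/C=C(\C)CCC=C(C)C)(C(=O)C(C(=O)c3ccc(O)c(O)c3)=C1O)C2=O` with > 20 ug/mL.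

Of the two numbers in this assay, compound 1 and compound 2 lie within the usual scatter of each other, so neither can be set apart from the other. Compound 3 gives only a limit in this assay, not a number, as recorded at the limit of > 20 ug/mL in this assay, at which 1 of the 3 values shown sits.

Compound 4 `CC(C)=CCC/C(C)=C/C[C@]12C[C@@H](CC=C(C)C)C(C)(C)[C@](CC=C(C)C)(C(=O)C(C(=O)c3ccc(O)c(O)c3)=C1O)C2=O` is not yet measured. It differs from compound 1 in one place: 3-methylbut-2-en-1-yl in place of hydrogen on a saturated chain carbon bound to a double-bonded chain carbon. The shared core is kept, and only one chain is lengthened.

Within the data shown here, no step between measured compounds is available to calibrate this change, so the expectation rests on the spread of the values shown. The step from compound 1 to compound 4 is expected to be small, within or only slightly beyond the scatter, in either direction; the estimate is a 1.3-fold higher number from compound 1 to compound 4 (0.11 log units; within the scatter). Compound 4 is therefore estimated at 12 ug/mL in this assay, with a range from 5 ug/mL to 25 ug/mL.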

Compound 4, half-maximal inhibitory concentration: 8.6 ug/mL
Compound 4: the middle estimate sits 1.4-fold (0.14 log units) above what was measured; low and high end bracket the measured number.
By their numbers in this assay, from the lowest: compounds 2, 4 and 1 (each within the scatter of the next). At a limit, above all of these: compound 3.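

In this assay, 3-methylbut-2-en-1-yl in place of hydrogen on a saturated chain carbon bound to a double-bonded chain carbon can be carried without a change that stands out from the scatter: a 1.1-fold lower number from compound 1 to compound 4 (0.03 log units; within the scatter). The reverse swap, hydrogen in place of 3-methylbut-2-en-1-yl at that kind of carbon, does not read the same from every starting compound, with an at least 2.3-fold lower number from compound 3 to compound 4 (0.36 log units; beyond the scatter) beyond the scatter and a 1.7-fold higher number from compound 2 to compound 4 (0.24 log units; within the scatter) within it. Compound 3 is a limit, not a number, so its step gives only a bound: the limit of > 20 ug/mL in this assay, at which 1 of the 4 values shown sits.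

Open, as far as these compounds go, is whether methyl, or a chain ending in an amine or a carboxylic acid, would be carried on this carbon as well as 3-methylbut-2-en-1-yl. Also open, from the compounds shown here alone, is how far the number for compound 3 lies from the others.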